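Small Heteroaromatic Rings in Place of the Nitrophenyl Amide

The compounds below may be only part of what the source reports. "The series", "measured", "known", "first", "only" and "open" are said of these compounds alone.

Compound 1 `O=C(NC(=S)N1CCc2c(OCCCCCOc3ccc(Cl)cc3)cccc21)c1ccc([N+](=O)[O-])cc1`: 13600 nM
Compound 2 `Cc1ccc(C(=O)NC(=S)N2CCc3c(OCCCCCOc4ccc(Cl)cc4)cccc32)cc1`: > 50000 nM, a limit of the assay
Compound 3 `O=C(NC(=S)N1CCc2c(OCCCCCOc3ccc(Cl)cc3)cccc21)c1ccco1`: 4620 nM

The three measured compounds share one core and differ only in the group on the carbonyl carbon. In an ADME assay on Huh-7 cells (Homo sapiens) for cytotoxicity (a higher number here means that more compound is tolerated, a lower number that less compound is tolerated), compound 1 gives 13600 nM, the highest of the two plain numbers. Compound 3 lies lower, as a 2.9-fold lower number from compound 1 to compound 3 (0.47 log units; beyond the scatter) shows. For compound 2 the assay reports only a limit, > 50000 nM, which is the limit of > 50000 nM in this assay, at which 1 of the 3 values shown sits.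

Compound 4 `O=C(NC(=S)N1CCc2c(OCCCCCOc3ccc(Cl)cc3)cccc21)c1ccno1` differs from compound 1 by 1,2-oxazol-5-yl in place of 4-nitrophenyl on a carbonyl carbon. Among the compounds with values here, the closest precedent is a 2.9-fold lower number from compound 1 to compound 3 (0.47 log units; beyond the scatter), where another five-membered aromatic ring took the place of the 4-nitrophenyl. A modest lowering is therefore expected, roughly a 2.3-fold lower number from compound 1 to compound 4 (0.36 log units; beyond the scatter). Compound 4 is estimated at 6000 nM, between 2500 nM and 20000 nM.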

Compound 4, half-maximal cytotoxic concentration: 37100 nM
For compound 4 the middle estimate is 6.2-fold (0.79 log units) below the measured one; measured number above the stated range.
By their numbers in this assay, from the lowest: compound 3; then compound 1; then compound 4. At a limit, above all of these: compound 2.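

In this assay a five-membered aromatic ring in place of the 4-nitrophenyl does not push the number in one fixed direction: 1,2-oxazol-5-yl raises it (a 2.7-fold higher number from compound 1 to compound 4 (0.44 log units; beyond the scatter)) and furan-2-yl lowers it (a 2.9-fold lower number from compound 1 to compound 3 (0.47 log units; beyond the scatter)). Exchanging one five-membered ring for the other raises the number again (an 8.0-fold higher number from compound 3 to compound 4 (0.90 log units; beyond the scatter)), so on this carbonyl carbon the identity of the ring counts, not only its size. With 1,2-oxazol-5-yl in place of 4-methylphenyl only a floor can be given (an at least 1.3-fold lower number from compound 2 to compound 4 (0.12 log units; that floor lies within the scatter)), so this step cannot be read as a difference. Compound 2 stands at a limit: the limit of > 50000 nM in this assay, at which 1 of the 4 values shown sits.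

Where a thiophene or a thiazole ring would fall relative to compound 3 and compound 4 stays open.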